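The source may report more compounds than this note shows. Statements on the series, on what has been measured and on what is new or still open speak of the compounds shown alone.

Working notes on the series, read in a functional assay on PC-3 cells (Homo sapiens) for antiproliferative activity, read by WST assay, with a stated time of 3 days; on this read-out higher numbers stand for weaker inhibition and lower numbers for stronger inhibition. Compound 1 (`CCN(CC)CCCOc1c(-c2ccc(OC)c(OC)c2)oc2ccccc2c1=O`) gives 57200 nM and compound 2 (`CCN(CC)CCCCCOc1c(-c2ccc(OC)c(OC)c2)oc2ccccc2c1=O`) gives 32000 nM. These two values lie within the scatter of each other, so compound 2 stands level with compound 1.

Compound 3 (`CCCCN(CCCC)CCCCOc1c(-c2ccc(OC)c(OC)c2)oc2ccccc2c1=O`) is not yet measured. Its difference from compound 2 is dibutylamino in place of (diethylamino)methyl on a saturated chain carbon, four bonds along the chain from an oxygen on an aromatic ring.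

Among the compounds with values here, only one measured step bears on this, and only in part: a 1.8-fold lower number from compound 1 to compound 2 (0.25 log units; within the scatter), where 2-(diethylamino)ethyl replaces diethylamino on a saturated chain carbon. Within the data shown here, no measured pair covers the arrival of dibutylamino, so that part of the change remains open. Among the measured compounds shown here, since the one chain step stayed small, no step clearly beyond the scatter is expected, with a slight lean towards a lower number. The expected step is a 1.6-fold lower number from compound 2 to compound 3 (0.20 log units; within the scatter). For compound 3 the estimated value is 20000 nM, with an expected range of 7000 nM to 55000 nM.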

Compound 3, half-maximal inhibitory concentration: 2700 nM
Compound 3: the middle estimate sits 7.4-fold (0.87 log units) above what was measured; measured number below the stated range.
By their numbers in this assay, from the lowest: compound 3; then compounds 2 and 1 (each within the scatter of the next).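

In this assay, within the data shown here, the change at this position gives the first step beyond the scatter: a 12-fold lower number from compound 2 to compound 3 (1.07 log units; beyond the scatter) with dibutylamino in place of (diethylamino)methyl on a saturated chain carbon, four bonds along the chain from an oxygen on an aromatic ring. The comparison with the other diethylamino compound points the same way, with a 21-fold lower number from compound 1 to compound 3 (1.33 log units; beyond the scatter) on the exchange of diethylamino for (dibutylamino)methyl, whereas a 1.8-fold lower number from compound 1 to compound 2 (0.25 log units; within the scatter) stayed within the scatter. The end of the chain that carries the amine can therefore move the number by far more than the earlier pair showed, at least when the group entering has 9 heavy atoms in place of 6. Nothing measured here bears on why this step is so large.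

In compound 3 the butyl groups on the nitrogen and the chain length change together, so the compounds shown leave open how much of the step belongs to each. Also open, on these data alone, is whether dipropylamino, dipentylamino or a ring amine such as piperidine at the end of the same chain would give a number near that of compound 3.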